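A few compounds are considered here, and "the series" means these few. Any claim that something is new, unique, unknown or untested is made for them only; others in the source may bear on it.

Compound 1 `Oc1cccc(-c2cc(-c3cccs3)cc(-c3cccc(O)c3)n2)c1`: 1690 nM in a functional assay on HeLa cells (Homo sapiens) for cytotoxicity, read by CCK-8 assay; on this read-out higher numbers stand for weaker inhibition and lower numbers for stronger inhibition
Compound 2 `Oc1cccc(-c2cc(-c3ccco3)cc(-c3cccc(O)c3)n2)c1`: 5990 nM
Compound 3 `Oc1cccc(-c2cc(-c3ccoc3)cc(-c3cccc(O)c3)n2)c1`: 4630 nM

Compound 3 stands second highest of these three numbers: it sits within the scatter of compound 2, as a 1.3-fold lower number from compound 2 to compound 3 (0.11 log units; within the scatter) shows, and beyond the scatter of compound 1, as a 2.7-fold higher number from compound 1 to compound 3 (0.44 log units; beyond the scatter) shows. Compound 4 `Oc1cccc(-c2cc(-c3ccccn3)cc(-c3cccc(O)c3)n2)c1` differs from compound 3 by pyridin-2-yl in place of furan-3-yl on an aromatic carbon. Among the compounds with values here, no measured step exchanges a five-membered ring for a six-membered one at this position. Within the data shown here, the steps that bear on it are the exchanges among five-membered rings: a 3.5-fold higher number from compound 1 to compound 2 (0.55 log units; beyond the scatter) and a 2.7-fold higher number from compound 1 to compound 3 (0.44 log units; beyond the scatter), both modest, and a 1.3-fold lower number from compound 2 to compound 3 (0.11 log units; within the scatter), within the scatter. A step of modest size in either direction is therefore the expectation, no larger. The expected step is a 1.3-fold lower number from compound 3 to compound 4 (0.12 log units; within the scatter). Compound 4 is estimated at 3500 nM, ranging from 1200 nM to 10000 nM.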

Compound 4, half-maximal inhibitory concentration: 6500 nM
Compound 4: middle estimate off by 1.9-fold (0.27 log units), on the low side; low and high end bracket the measured number.
By their numbers in this assay, from the lowest: compound 1; then compounds 3, 2 and 4 (each within the scatter of the next).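

Pyridin-2-yl, the first six-membered aromatic ring at this position, stays within the scatter of both furans (a 1.4-fold higher number from compound 3 to compound 4 (0.15 log units; within the scatter); a 1.1-fold higher number from compound 2 to compound 4 (0.04 log units; within the scatter)), so the change in ring size brings no separate step here. Only thiophen-2-yl stands apart from it (a 3.8-fold higher number from compound 1 to compound 4 (0.59 log units; beyond the scatter)), leaving compound 1 alone at the low end of the four numbers. No evidence on the cause of this pattern is at hand.

Open, going by these compounds, is whether a plain phenyl ring or a thiazole at this position would fall with compound 1 or with the other three. Also open, on these data alone, is how an open-chain amine or a carboxylic acid there would read.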